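Ester variation on a quinone core and expected cytotoxicity

The compounds below may be only part of what the source reports. "The series", "measured", "known", "first", "only" and "open" are said of these compounds alone.

Of the compounds shown here, three sharing one core have been measured in a functional assay on HeLa cells (Homo sapiens) for cytotoxicity, read by MTT assay; a lower number here means a stronger inhibitor, a higher number a weaker inhibitor. Compound 1 `CCCCC(O)CC(=O)O[C@H](CC=C(C)C)C1=CC(=O)c2c(O)ccc(O)c2C1=O` gives 72200 nM in this assay. Compound 2 `CC(C)=CC[C@@H](OC(=O)C1CCOC1)C1=CC(=O)c2c(O)ccc(O)c2C1=O` gives 73500 nM, the highest of the three numbers, though its neighbours sit close: the step of a 1.0-fold higher number from compound 1 to compound 2 (0.01 log units; within the scatter) and the step of a 1.2-fold lower number from compound 2 to compound 3 (0.08 log units; within the scatter) are both within the scatter. Compound 3 `CCCCC(C)(O)CC(=O)O[C@H](CC=C(C)C)C1=CC(=O)c2c(O)ccc(O)c2C1=O` gives 60600 nM in this assay, and the step of a 1.2-fold lower number from compound 1 to compound 3 (0.08 log units; within the scatter) is likewise within the scatter.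

Compound 4 `CCC(O)(CC)CC(=O)O[C@H](CC=C(C)C)C1=CC(=O)c2c(O)ccc(O)c2C1=O` has not yet been measured. It differs from compound 2 as follows: 2-ethyl-2-hydroxybutyl in place of oxolan-3-yl on a carbonyl carbon. The measured steps that bear on this change are those from compound 1 to compound 2 and from compound 2 to compound 3, both of which swap the group on the carbonyl carbon between a ring and a hydroxy-bearing chain and both of which stayed within the scatter. No step beyond the scatter is therefore expected for compound 4 in this assay. Compound 4 is estimated at 65000 nM, within 35000 nM to 120000 nM, which means an expected step of a 1.1-fold lower number from compound 2 to compound 4 (0.05 log units; within the scatter).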

Compound 4, half-maximal inhibitory concentration: 52000 nM
Compound 4: the middle estimate sits 1.3-fold (0.10 log units) above what was measured, within the range that was stated.
By their numbers in this assay, from the lowest: compounds 4, 3, 1 and 2 (each within the scatter of the next).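

In this assay, the exchange of oxolan-3-yl on the carbonyl carbon for 2-ethyl-2-hydroxybutyl, which has no ring and adds a hydrogen-bond donor, gives a 1.4-fold lower number from compound 2 to compound 4 (0.15 log units; within the scatter), so this larger swap also leaves the reading inside the scatter. The open hydroxy chains stay together as well: 1-ethyl-1-hydroxypropyl in place of 1-hydroxy-1-methylpentyl gives a 1.2-fold lower number from compound 3 to compound 4 (0.07 log units; within the scatter), and in place of 1-hydroxypentyl it gives a 1.4-fold lower number from compound 1 to compound 4 (0.14 log units; within the scatter). Nothing available accounts for this flat picture at the position.

From the compounds shown here alone, all four groups on the carbonyl carbon carry no net charge, so it remains open whether an amine or a carboxylic acid there would produce a step beyond the scatter. Also open, going by these compounds, is what a phenyl ring in this place would do.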